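This account rests on a few compounds, and the source may have more. Where it says the series, first, only, none or still open, it means among the compounds named here.

In a functional assay on PC-3 cells (Homo sapiens) for cytotoxicity, read by MTT assay, with a stated time of 48 h (on this read-out higher numbers stand for weaker inhibition and lower numbers for stronger inhibition), compound 3 (`O=C(O)CN1C(=O)/C(=C/c2nc3ccccc3n2Cc2ccccc2)SC1=S`) gives 10800 nM, level within the scatter with compound 1 (`N#Cc1ccc(Cn2c(/C=C3\SC(=S)N(CC(=O)O)C3=O)nc3ccccc32)cc1`) at 14400 nM, whereas compound 2 (`O=C(O)CN1C(=O)/C(=C/c2nc3ccccc3n2Cc2ccc(F)cc2)SC1=S`) gives a lower 4860 nM. Compound 4 (`O=C(O)CN1C(=O)/C(=C/c2nc3ccccc3n2Cc2ccc(C(F)(F)F)cc2)SC1=S`) has trifluoromethyl in place of hydrogen on an aromatic carbon, para to a large group: trifluoromethyl in place of hydrogen on an aromatic carbon. For the measured compounds named here, two measured steps bear on this change, both ending at hydrogen: a 1.3-fold lower number from compound 1 to compound 3 (0.12 log units; within the scatter) from cyano, within the scatter, and a 2.2-fold higher number from compound 2 to compound 3 (0.35 log units; beyond the scatter) from fluoro, modest and beyond it. These two steps do not agree, so no change beyond the scatter is expected in this assay. The estimated step is a 1.4-fold lower number from compound 3 to compound 4 (0.13 log units; within the scatter). For compound 4 the expected value is 8000 nM, with an estimated range of 3500 nM to 18000 nM.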

Compound 4, half-maximal inhibitory concentration: 22900 nM
For compound 4 the middle estimate is 2.9-fold (0.46 log units) below the measured one; the whole stated range lies below it.
By their numbers in this assay, from the lowest: compound 2; then compounds 3, 1 and 4 (each within the scatter of the next, the first and the last beyond it).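

In this assay a group on this aromatic carbon, para to a large group, can move the number up as well as down: trifluoromethyl in place of hydrogen gives a 2.1-fold higher number from compound 3 to compound 4 (0.33 log units; beyond the scatter), the opposite direction to fluoro. For the compounds shown here, replacing fluoro with trifluoromethyl gives a 4.7-fold higher number from compound 2 to compound 4 (0.67 log units; beyond the scatter), the widest step so far. Replacing cyano with trifluoromethyl gives a 1.6-fold higher number from compound 1 to compound 4 (0.20 log units; within the scatter), so these two groups stand level.

On these data alone, whether a methoxy group or an amine on this carbon would side with fluoro or with trifluoromethyl stays open. No measurement at hand accounts for these differences.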